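The source may hold more compounds than are shown below. What is called first, only, known or untested is meant among the compounds shown, and "the series" means these compounds.

Working notes on the series. Compound 1 `Cc1cc(NCc2ccccn2)n2nc(C)c(-c3ccc(F)cc3)c2n1` was run in a physicochemical assay for solubility, read by HPLC, using the shake flask method, measured as kinetic solubility, with a stated time of 2 h, at pH 7.4; a higher number here means a more soluble compound, a lower number a less soluble compound; in this assay compound 1 gives only a limit, < 5000 nM. Compound 2 `Cc1cc(NCc2ncc[nH]2)n2nc(C)c(-c3ccccc3)c2n1` likewise gives only a limit in this assay, < 5000 nM. Among the measured compounds shown here, compound 3 `Cc1cc(NCc2ccccn2)n2ncc(-c3ccccc3F)c2n1` gives 5000 nM in this assay, the one actual number among the three. For the measured compounds named here, the other two values stop at the limit of < 5000 nM in this assay, at which 2 of the 3 values shown sit, so no order among compounds 1, 2 and 3 can be read off, and no step between measured compounds is available to set a scale.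

Compound 4 `Cc1cc(NCc2ccccn2)n2ncc(-c3ccncc3)c2n1` is not yet measured. It differs from compound 3 by pyridin-4-yl in place of 2-fluorophenyl on an aromatic carbon; as counted, pyridin-4-yl carries one hydrogen-bond acceptor where 2-fluorophenyl carries none. Going by the values given here, with no measured step in this assay to lean on, the expectation rests on compound 3 alone, which gives 5000 nM. In this assay compound 4 is expected to come in at 12000 nM, with a range of 4000 nM to 40000 nM. The expected step, a 2.4-fold higher number from compound 3 to compound 4 (0.38 log units; beyond the scatter), is estimated as a moderate rise rather than a settled change, and a limit reading remains possible.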

Compound 4, solubility: 161000 nM
Estimate against measurement, compound 4: 13-fold (1.13 log units) below; the measured number lies above the stated range.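

Pyridin-4-yl in place of 2-fluorophenyl on this aromatic carbon gives a 32-fold higher number from compound 3 to compound 4 (1.51 log units; beyond the scatter) in this assay and is the first step in the series that can be read. It shows that the group on this carbon can shift the read-out by a large margin, in a change that, as counted, brings in a hydrogen-bond acceptor and removes the fluorine. Among the compounds shown here, compounds 1 and 2 give only limits, so no steps involving them can be read: the limit of < 5000 nM in this assay, at which 2 of the 4 values shown sit.

For the compounds shown here, whether the step follows the ring nitrogen or the loss of fluorine stays open, as both come in the one change. The compounds shown do not say how a pyridin-3-yl or a morpholine-bearing group on this carbon would read, nor how this change reads with the methyl present in compounds 1 and 2.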